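The compounds below may be only part of what the source reports. "The series", "measured", "known", "first", "only" and "open" are said of these compounds alone.

Working notes on a short series sharing one core. In a functional assay on the whole organism for inhibition, with Mus musculus as the target, at a dose of 25 mg/kg by the oral route (a lower number here means less inhibition, a higher number more inhibition at the dose given (going by the name of the read-out)), compound 1 `c1ccc(N2CCN(CCCCOc3ccc4c(c3)CCC4)CC2)cc1` gives 75%, compound 2 `Fc1cccc(N2CCN(CCCCOc3ccc4c(c3)CCC4)CC2)c1` gives 15%, and compound 3 `Clc1ccc(N2CCN(CCCCOc3ccc4c(c3)CCC4)CC2)cc1` gives 31%. Compound 3 therefore stands second highest of the three numbers, with compound 2 nearest to it and compound 1 furthest from it. Both steps that place a halogen on the aromatic ring are large and downward: a number 60 percentage points lower from compound 1 to compound 2 (beyond the scatter) and a number 44 percentage points lower from compound 1 to compound 3 (beyond the scatter). Between the two halogenated analogues the difference is smaller: a number 16 percentage points higher from compound 2 to compound 3 (beyond the scatter).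

Compound 4 `Clc1cc(Cl)cc(N2CCN(CCCCOc3ccc4c(c3)CCC4)CC2)c1` has yet to be measured in this assay. Its change from compound 3: 3,5-dichlorophenyl in place of 4-chlorophenyl on an amine nitrogen in a ring. Among the measured compounds shown here, no measured step adds a second halogen to a ring that already carries one, so the nearest guides are the two halogen steps, a number 60 percentage points lower from compound 1 to compound 2 (beyond the scatter) and a number 44 percentage points lower from compound 1 to compound 3 (beyond the scatter), both of which brought the number well down, while the shift between two halogen patterns, a number 16 percentage points higher from compound 2 to compound 3 (beyond the scatter), was only modest. A further modest decrease is therefore expected, with the step estimated as a number 11 percentage points lower from compound 3 to compound 4 (beyond the scatter). Because compound 3 already sits at 31%, the room for a large fall is limited. Compound 4 is estimated at 20%, within a range from 0% to 50%.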

Compound 4, a percentage reported as inhibition, in the whole organism at one dose (the size of the read-out at that dose, not a potency): 0%
Estimate against measurement, compound 4: 20 percentage points above; low and high end bracket the measured number.
By their numbers in this assay, from the lowest: compound 4; then compound 2; then compound 3; then compound 1.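

In this assay the change to 3,5-dichlorophenyl gives a number 31 percentage points lower from compound 3 to compound 4 (beyond the scatter) as a large step, so the number still falls when the aryl group on the ring amine nitrogen already carries a chlorine, although this step alters both the count and the placing of chlorine and cannot say which of the two matters. Against the fluorinated analogue the change is modest, with a number 15 percentage points lower from compound 2 to compound 4 (beyond the scatter) in this read-out, and against the unsubstituted phenyl it is large, with a number 75 percentage points lower from compound 1 to compound 4 (beyond the scatter) across the series, which makes compound 4 the lowest of the four and leaves all three halogenated aryl groups well under the plain phenyl. Nothing at hand gives a reason for this fall.

Open, from the compounds shown here alone, is whether the loss belongs to halogens or to any group on this phenyl ring, which a methyl or methoxy group could test, and whether 3-chlorophenyl would separate the placing of chlorine from its count. Also open, going by these compounds, is whether the same order of aryl groups would hold with a longer chain in the shared core.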